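Dropping the Iodo Group From an Aminophenyl Growth Inhibitor

This account rests on a few compounds, and the source may have more. Where it says the series, first, only, none or still open, it means among the compounds named here.

Compound 1 `Nc1ccc(-c2nc3cc(F)ccc3s2)cc1I`: 10200 nM
Compound 2 `Nc1ccc(-c2nc3ccc(F)cc3s2)cc1Cl`: 14100 nM

In a functional assay on NCI-H226 cells (Homo sapiens) for inhibition (on this read-out higher numbers stand for weaker inhibition of growth and lower numbers for stronger inhibition of growth), compound 1 gives 10200 nM. Compound 2 gives 14100 nM, and the gap between the two lies within the scatter, so neither can be called the stronger. Compound 3 `Nc1ccc(-c2nc3cc(F)ccc3s2)cc1` differs from compound 1 by hydrogen in place of iodo on an aromatic carbon. Among the measured compounds shown here, no pair of measured compounds shows this change, so its effect is unknown here. The expectation is that the step of a 2.2-fold higher number from compound 1 to compound 3 (0.33 log units; beyond the scatter) runs toward a higher number, somewhat beyond the scatter. Compound 3 is therefore estimated at 22000 nM in this assay, within 7000 nM to 70000 nM.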

Compound 3, concentration for 50% growth inhibition: < 10 nM
Compound 3: no number, only a limit; the forecaster's own chance of this, stated with the estimate: 12%; middle value at least 2200-fold (3.34 log units) from the limit.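

In this assay compound 3 gives < 10 nM, which is a limit of the assay and not a number. Hydrogen in place of iodo, on the aromatic carbon ortho to an amino group, gives an at least 1000-fold lower number from compound 1 to compound 3 (3.00 log units; beyond the scatter), so this single position can govern the read-out on a scale that the earlier compounds did not reveal. The true size of the step stays unfixed: the limit of < 10 nM in this assay, at which 1 of the 3 values shown sits.

From the compounds shown here alone, whether a methyl or methoxy group on this carbon would keep the low number stays open. So does whether hydrogen in place of chloro in compound 2 would act in the same way.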